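Thiourea to urea on a fused thiophene core

The source may hold more compounds than are shown below. What is called first, only, known or untested is meant among the compounds shown, and "the series" means these compounds.

Compound 1 `N#Cc1ccccc1CN1CCc2c(sc(NC(=O)c3ccccc3Cl)c2C(N)=O)C1` in a functional assay on MKN-74 cells (Homo sapiens) for antiproliferative activity, with a stated time of 24 h; on this read-out lower numbers stand for stronger inhibition and higher numbers for weaker inhibition: 9500 nM
Compound 2 `CSc1ccccc1NC(=S)N1CCc2c(sc(NC(=O)c3ccccc3Cl)c2C(N)=O)C1` in this assay: 13800 nM
Compound 3 `NC(=O)c1c(NC(=O)c2ccccc2Cl)sc2c1CCN(C(=S)Nc1c(Cl)cccc1Cl)C2` in this assay: 4020 nM

Compound 3 gives the lowest number of the three. The steps to it are a 2.4-fold lower number from compound 1 to compound 3 (0.37 log units; beyond the scatter) and a 3.4-fold lower number from compound 2 to compound 3 (0.54 log units; beyond the scatter), both beyond the scatter, while a 1.5-fold higher number from compound 1 to compound 2 (0.16 log units; within the scatter) lies within it. Compound 4 `NC(=O)c1c(NC(=O)c2ccccc2Cl)sc2c1CCN(C(=O)Nc1c(Cl)cccc1Cl)C2` keeps the 2,6-dichlorophenyl and changes only the linking unit: a group of 11 heavy atoms (7 carbon, 1 nitrogen, 1 oxygen, 2 chlorine; one six-membered aromatic ring of carbon only) in place of a group of 11 heavy atoms (7 carbon, 1 nitrogen, 1 sulfur, 2 chlorine; one six-membered aromatic ring of carbon only), on an amine nitrogen in a ring. Among the compounds with values here, no measured step exchanges a thiocarbonyl for a carbonyl; the measured steps vary either the whole group on the ring nitrogen or the aryl ring on the amide-type nitrogen, and their spread is modest at most. They bear on the present change only in showing that this part of the molecule shifts the number modestly. A small step is therefore expected, a 1.4-fold higher number from compound 3 to compound 4 (0.14 log units; within the scatter), not clearly beyond the scatter in either direction. For compound 4 the estimate in this assay is 5500 nM, with a range of 1800 nM to 17000 nM.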

Compound 4, half-maximal inhibitory concentration: 24400 nM
Compound 4: the middle estimate sits 4.4-fold (0.65 log units) below what was measured; measured number outside the range, above it.
By their numbers in this assay, from the lowest: compound 3; then compounds 1, 2 and 4 (each within the scatter of the next, the first and the last beyond it).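

With the 2,6-dichlorophenyl held fixed, the exchange of thiocarbonyl for carbonyl isolates the linking unit in this assay and gives a 6.1-fold higher number from compound 3 to compound 4 (0.78 log units; beyond the scatter), a larger move than any earlier step. What set compound 3 apart therefore does not carry over to its urea counterpart: the other two comparisons give a 1.8-fold higher number from compound 2 to compound 4 (0.25 log units; within the scatter) and a 2.6-fold higher number from compound 1 to compound 4 (0.41 log units; beyond the scatter), the first within the scatter and the second beyond it. Nothing available explains why this exchange matters so much here.

From the compounds shown here alone, whether the same exchange acts alike with another aryl group, such as 2-(methylsulfanyl)phenyl, remains open, as this single pair cannot settle it. Also open, going by these compounds, is how a guanidine or a sulfonyl link would read in place of the thiocarbonyl or carbonyl.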